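This account rests on a few compounds, and the source may have more. Where it says the series, first, only, none or still open, it means among the compounds named here.

Values in a functional assay on HepG2 cells (Homo sapiens) for antiproliferative activity, read by MTT assay, with a stated time of 72 h; on this read-out higher numbers stand for weaker inhibition and lower numbers for stronger inhibition:
- compound 1 `Cc1ccc2c(c1)N(S(=O)(=O)c1ccc(-c3cnc(C4CC4)o3)cc1)CCCO2` gives 31 nM
- compound 2 `Cc1ccc2c(c1)OCCCN2S(=O)(=O)c1ccc(-c2cnc(C3CC3)o2)cc1` gives 795 nM
- compound 3 `COc1ccc2c(c1)N(S(=O)(=O)c1ccc(-c3cnc(C4CC4)o3)cc1)CCCO2` gives 49 nM

Compound 1 and compound 2 are built from the same atoms joined differently; the difference between the two cores is not broken down here. Compound 2 stands highest of the three, with compound 3 and compound 1 both well below it, beyond the scatter. Among the compounds with values here, the one counted change in the set is methoxy in place of methyl on an aromatic carbon, which gave a 1.6-fold higher number from compound 1 to compound 3 (0.20 log units; within the scatter). The same change, (methoxy in place of methyl on an aromatic carbon), at a place described in the same words, leads from compound 2 to the unmeasured compound 4 `COc1ccc2c(c1)OCCCN2S(=O)(=O)c1ccc(-c2cnc(C3CC3)o2)cc1`. Resting on the single precedent a 1.6-fold higher number from compound 1 to compound 3 (0.20 log units; within the scatter), the step is expected to be a 1.4-fold higher number from compound 2 to compound 4 (0.14 log units; within the scatter). In this assay compound 4 is therefore estimated at 1100 nM, with a likely range from 450 nM to 2700 nM.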

Compound 4, half-maximal inhibitory concentration: 229 nM
Compound 4: middle estimate off by 4.8-fold (0.68 log units), on the high side; measured number outside the range, below it.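

In this assay methoxy in place of methyl on an aromatic carbon gives a 3.5-fold lower number from compound 2 to compound 4 (0.54 log units; beyond the scatter), a step beyond the scatter on this core. With a single pair on each core, this shows that the step measured on one core did not carry over unchanged to the other, but it does not show why, or how a further core would respond. The two steps differ by more than the scatter of two such steps: the same change on two cores in this assay, a 1.6-fold higher number (0.20 log units; within the scatter) from compound 1 to compound 3 and a 3.5-fold lower number (0.54 log units; beyond the scatter) from compound 2 to compound 4, 5.5-fold (0.74 log units) apart, beyond the scatter of two such steps

Going by these compounds, whether the cores also part ways for other groups at this aromatic carbon stays open, for example chlorine, trifluoromethyl or an amine. A longer alkoxy chain such as ethoxy would test whether the gap persists beyond methoxy.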